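The compounds below may be only part of what the source reports. "The series", "measured", "known", "first", "only" and "open" are said of these compounds alone.

Measured compounds:
compound 1, `COCCOC(=O)C1=C(C)NC(C)=C(C(=O)OCCOC)C1c1cnc(SC)n1Nc1ccccc1`: 17.9 nM
compound 2, `CSc1ncc(C2C(C(=O)OC3CCCCC3)=C(C)NC(C)=C2C(=O)OC2CCCCC2)n1Nc1ccccc1`: 465 nM

Compound 1 has the lowest number of the two in an assay on isolated protein (strain albino) for antagonist activity at Voltage-dependent L-type calcium channel subunit alpha-1C (Cavia porcellus); on this read-out lower numbers stand for stronger inhibition and higher numbers for weaker inhibition; compound 2 sits well beyond the scatter above it. Compound 3, `CCOC(=O)C1=C(C)NC(C)=C(C(=O)OCCOC)C1c1cnc(SC)n1Nc1ccccc1`, has not yet been measured. It differs from compound 1 in one place: hydrogen in place of methoxy on a saturated chain carbon, two bonds along the chain from an oxygen next to a carbonyl group. Within the data shown here, no measured pair shows this change, so the step is uncertain. Because compound 1 gives 17.9 nM, a small step near the scatter is expected from compound 1 to compound 3, a 1.3-fold lower number from compound 1 to compound 3 (0.11 log units; within the scatter). Compound 3 is estimated at 14 nM, within 5 nM to 45 nM.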

Compound 3, half-maximal inhibitory concentration: 2.91 nM
Beside the measured number, compound 3's estimate is 4.8-fold (0.68 log units) above it; measured number outside the range, below it.
By their numbers in this assay, from the lowest: compound 3; then compound 1; then compound 2.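

In this assay, cutting 2-methoxyethoxy to ethoxy gives a 6.2-fold lower number from compound 1 to compound 3 (0.79 log units; beyond the scatter) and shows that this position responds to the change. The methoxy is not required for a low number here, and its removal alone moves the read-out. No available evidence accounts for the size of this step.

The compounds shown leave open whether the remaining 2-methoxyethoxy group responds in the same way. They also do not show how a longer chain, an amine or a carboxylic acid at this place would read.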